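The compounds below may be only part of what the source reports. "The series", "measured", "known", "first", "only" and "open" are said of these compounds alone.

Measured compounds:
compound 1, `NCCCCN(C[C@H]1Cc2ncccc2CN1)[C@H]1CCCc2cccnc21` — 100%
compound 2, `NC/C=C\CN(C[C@H]1Cc2ncccc2CN1)[C@H]1CCCc2cccnc21` — 85%
compound 3, `NC/C=C/CN(C[C@H]1Cc2ncccc2CN1)[C@H]1CCCc2cccnc21` — 85%

In an ADME assay on microsomes from liver (Homo sapiens) for metabolic stability, using NADPH, with a stated time of 10 min (on this read-out higher numbers stand for a more stable compound and lower numbers for a less stable compound), compound 1 stands highest of the three, with compound 2 and compound 3 each below it. The two steps recorded, a number 15 percentage points lower from compound 1 to compound 2 (beyond the scatter) and a number 15 percentage points lower from compound 1 to compound 3 (beyond the scatter), both come from the same change, 3-aminoprop-1-en-1-yl in place of 3-aminopropyl on a saturated chain carbon bound to an amine nitrogen. The pair of compound 2 and compound 3 shows no change at the digits printed from compound 2 to compound 3 (within the scatter), which agrees with the fact that compounds 2 and 3 differ only in the configuration as drawn.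

Compound 4, `CCN(CC)CCCCN(C[C@H]1Cc2ncccc2CN1)[C@H]1CCCc2cccnc21`, is a different kind of variation of compound 1: diethylamino in place of amino on a saturated chain carbon, four bonds along the chain from an amine nitrogen. For the measured compounds named here, no measured step touches the end of the chain in this way, so the recorded steps give only a loose guide. Since compound 1 already sits at the top of the scale, the step can only hold or fall. Compound 4 is expected to give about 80%, within 50% to 100%. The expected step is a number 20 percentage points lower from compound 1 to compound 4 (beyond the scatter).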

Compound 4, percent of the compound remaining: 80%
Compound 4: middle estimate and measured number agree at the digits printed; the measured number falls inside the stated range.
By their numbers in this assay, from the lowest: compounds 4, 2 and 3 (each within the scatter of the next); then compound 1.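

Diethylamino in place of amino at the end of the chain also moves the read-out in this assay, giving a number 20 percentage points lower from compound 1 to compound 4 (beyond the scatter), so the end of the chain is a second place where a change registers, alongside the unsaturation of the chain. Although compound 4 keeps the saturated chain of compound 1, the printed steps to the unsaturated compounds are a number 5 percentage points lower from compound 3 to compound 4 (within the scatter) and a number 5 percentage points lower from compound 2 to compound 4 (within the scatter), so the two kinds of change cannot be told apart by size here. Nothing available bears on the reason for the step to compound 4.

The compounds shown leave open whether methylamino or dimethylamino at the chain end would stay closer to compound 1 than diethylamino does. They also leave open how a piperidine or an amide in that place would compare, and whether a longer chain would change the picture.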